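Ester removal from compound 1 under the cell assay

The compounds below may be only part of what the source reports. "The series", "measured", "known", "first", "only" and "open" are said of these compounds alone.

Measured in a functional assay on A549 cells (Homo sapiens) for inhibition, read by MTT assay, with a stated time of 72 h; on this read-out higher numbers stand for weaker inhibition and lower numbers for stronger inhibition:
compound 1 `CCC(=O)O[C@@H](/C(C)=C/[C@@H](C)c1oc(CC)c(C)c(=O)c1C)[C@H](C)[C@@H](OC(=O)CC(C)C)[C@@H](C)c1oc([C@@H](C)[C@@H](O)CC)c(C)c(=O)c1C`: 12000 nM
compound 2 `CCc1oc([C@H](C)/C=C(\C)[C@H](OC(C)=O)[C@H](C)[C@@H](OC(=O)CC(C)C)[C@@H](C)c2oc([C@@H](C)[C@H](CC)OC(C)=O)c(C)c(=O)c2C)c(C)c(=O)c1C`: 28000 nM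
compound 3 `CCC(=O)[C@@H](C)c1oc([C@H](C)[C@@H]2O[C@](O)([C@@H](C)c3oc(CC)c(C)c(=O)c3C)[C@@H](C)[C@@H](O)[C@@H]2C)c(C)c(=O)c1C`: > 100000 nM

Compound 1 holds the lower of the two actual numbers in this assay, and so shows the stronger inhibition of that pair. At 12000 nM compound 1 stands clear of compound 2 at 28000 nM, a gap beyond the usual scatter. Compound 3 gives > 100000 nM, which is a limit of the assay and not a number.

The next compound to be tested is compound 4 `CCc1oc([C@H](C)/C=C(\C)[C@H](O)[C@H](C)[C@@H](OC(=O)CC(C)C)[C@@H](C)c2oc([C@@H](C)[C@@H](O)CC)c(C)c(=O)c2C)c(C)c(=O)c1C`. It differs from compound 1 in one place: hydrogen in place of propanoyl on an oxygen on a saturated carbon. Propanoyloxy thus becomes hydroxy, while the rest of the structure stays the same. For the measured compounds named here, no measured pair of compounds isolates this change, so the expectation is only tentative. Starting from compound 1 at 12000 nM, a modest move towards weaker inhibition in this assay seems more likely than a large one, and a result within the scatter would not be surprising. The expected change is a 1.7-fold higher number from compound 1 to compound 4 (0.22 log units; within the scatter). For compound 4 the estimated value is 20000 nM, with an expected range from 7000 nM to 60000 nM.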

Compound 4, half-maximal inhibitory concentration: > 100000 nM
Compound 4: only a limit was reported; the forecaster's own chance of this, stated with the estimate: 15%; at least 5.0-fold (0.69 log units) between middle value and limit.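

The step shows that the propanoyl on this oxygen on a saturated carbon is not a silent part of compound 1: with hydrogen in its place, so that propanoyloxy becomes hydroxy, this assay records an at least 8.3-fold higher number from compound 1 to compound 4 (0.92 log units; beyond the scatter). For the compounds shown here, this is the first pair in the set that differs in one place, so the earlier compounds could not tie any change in inhibition to this position, and here the single change is enough to leave no actual number for the product. The value of compound 4, > 100000 nM, is a limit of the assay and not a number, so the step gives only a lower bound on the size of the change, and the full size cannot be read: the limit of > 100000 nM in this assay, at which 2 of the 4 values shown sit.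

The compounds shown leave open whether inhibition at this oxygen depends on propanoyl itself or would be kept by another acyl group, such as a longer chain like butanoyl or a benzoyl group. They also leave open what an amine in place of the hydroxy of compound 4 would do in this assay.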